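Trading a branched tail for a straight one

The source may hold more compounds than are shown below. What is called first, only, known or untested is meant among the compounds shown, and "the series" means these compounds.

Three compounds share a core and differ in the group carried on the imidazole ring. Compound 1 `CCCCc1cnc(C(CCC)Cc2ccc(-c3ccccc3C(=O)O)cc2)[nH]1` gives 165 nM in an in vitro functional assay on cells for agonist activity at Bombesin receptor subtype-3 (Mus musculus), read by luminescence and calcium flux; a lower number here means that less compound is needed, a higher number that more compound is needed for the effect. Compound 2 `O=C(O)c1ccccc1-c1ccc(CCc2ncc(C3CCCCC3)[nH]2)cc1` gives 14.7 nM in the same assay, and compound 3 `CC(C)(C)Cc1cnc(CCc2ccc(-c3ccccc3C(=O)O)cc2)[nH]1` gives 6.3 nM, the lowest of the three numbers; compound 2 sits nearest to it and compound 1 furthest. For the measured compounds named here, the one single-change step measured so far, a 2.3-fold lower number from compound 2 to compound 3 (0.37 log units; beyond the scatter), shows that swapping cyclohexyl for neopentyl moved the number by a modest but real amount.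

Compound 4 `CCCCc1cnc(CCc2ccc(-c3ccccc3C(=O)O)cc2)[nH]1` is the next step: propyl in place of tert-butyl on a saturated chain carbon bound to an aromatic carbon. Read one bond further out, this is neopentyl to butyl. Going by the values given here, no measured pair isolates this exact change; compound 1 also carries butyl on the ring but differs from compound 3 in a second place as well. The value of compound 1, 165 nM, can therefore only hint. Given that compound 3 reached 6.3 nM after a 2.3-fold lower number from compound 2 to compound 3 (0.37 log units; beyond the scatter), the step from compound 3 to compound 4 is expected to be a 2.4-fold higher number from compound 3 to compound 4 (0.38 log units; beyond the scatter), a modest rise. Compound 4 is therefore estimated at 15 nM, with a likely range from 5 nM to 50 nM.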

Compound 4, half-maximal effective concentration: 93 nM
For compound 4 the middle estimate is 6.2-fold (0.79 log units) below the measured one; the measured number lies above the stated range.
By their numbers in this assay, from the lowest: compound 3; then compound 2; then compounds 4 and 1 (each within the scatter of the next).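

Losing the branch is costly at this position: with propyl (3 heavy atoms) in place of tert-butyl (4 heavy atoms), this assay shows a far larger shift (a 15-fold higher number from compound 3 to compound 4 (1.17 log units; beyond the scatter)) than the earlier swap of cyclohexyl for neopentyl. Butyl also falls behind cyclohexyl (a 6.3-fold higher number from compound 2 to compound 4 (0.80 log units; beyond the scatter)), so among these three groups, the straight chain needs the most compound for the effect. The propyl on the saturated chain carbon, by contrast, makes no difference that can be told from the scatter when butyl is present (a 1.8-fold lower number from compound 1 to compound 4 (0.25 log units; within the scatter)). Nothing measured here accounts for why the branched tail and the straight tail differ so much. Still open, as far as these compounds go, is how a longer chain such as hexyl, or a tail ending in an amine, would compare, and whether that propyl would matter alongside neopentyl.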